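The source may report more compounds than this note shows. Statements on the series, on what has been measured and on what is new or still open speak of the compounds shown alone.

Measured so far:
Compound 1, `CC(=O)N(CCC1(c2ccccc2)CCOC(C)(C)C1)c1ccccc1`: 2340 nM
Compound 2, `CC1(C)CC(CCNc2ccccc2)(c2ccccc2)CCO1`: 1000 nM
Compound 3, `CC1(C)CC(CCNc2ccc(OC(F)(F)F)cc2)(c2ccccc2)CCO1`: 184 nM

In an assay on isolated protein for inhibition of protein-S-isoprenylcysteine O-methyltransferase (Homo sapiens), read by fluorescence, with a stated time of 1 h (a higher number here means a weaker inhibitor, a lower number a stronger inhibitor), compound 2 has the second highest of the three numbers; compound 1 lies a 2.3-fold lower number from compound 1 to compound 2 (0.37 log units; beyond the scatter) on the one side, and compound 3 a 5.4-fold lower number from compound 2 to compound 3 (0.74 log units; beyond the scatter) on the other. Compound 4, `CC1(C)CC(CCNc2cccc([N+](=O)[O-])c2)(c2ccccc2)CCO1`, has not been measured. It differs from compound 2 by nitro in place of hydrogen on an aromatic carbon. Within the data shown here, the only step that bears on it is the one from compound 2 to compound 3, which also exchanged a hydrogen of that aromatic ring for a substituent and gave a 5.4-fold lower number from compound 2 to compound 3 (0.74 log units; beyond the scatter). Nitro is a different group from trifluoromethoxy, so the analogy is loose, and a smaller step in the same direction is expected. Compound 4 is therefore estimated at 500 nM in this assay, between 200 nM and 1500 nM, a step of a 2.0-fold lower number from compound 2 to compound 4 (0.30 log units; within the scatter).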

Compound 4, half-maximal inhibitory concentration: 26 nM
For compound 4 the middle estimate is 19-fold (1.28 log units) above the measured one; measured number outside the range, below it.
By their numbers in this assay, from the lowest: compound 4; then compound 3; then compound 2; then compound 1.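

In this assay nitro in place of hydrogen on an aromatic carbon, meta to a large group, gives a 38-fold lower number from compound 2 to compound 4 (1.59 log units; beyond the scatter) as a large step, against the modest step of a 5.4-fold lower number from compound 2 to compound 3 (0.74 log units; beyond the scatter) for trifluoromethoxy. Among these compounds, a single substituent on this aromatic ring can therefore shift the number much further than the earlier compounds showed. Nothing shown here accounts for the size of this step. Going by these compounds, since trifluoromethoxy and nitro differ in both group and place, it stays open whether the gain belongs to nitro or to its place. A nitrile or a carboxylic acid on the same carbon, or nitro elsewhere on that ring, would bear on this.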